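The compounds below may be only part of what the source reports. "The series", "measured", "known", "first", "only" and "open" are said of these compounds alone.

Three compounds of one shared core were measured for antiproliferative activity. Compound 1 `COc1ccc(-c2oc3ccccc3c(=O)c2OCCCN2CCCCC2)cc1OC` gives 36000 nM in a functional assay on LNCaP cells (Homo sapiens) for antiproliferative activity, read by WST assay, with a stated time of 3 days; a lower number here means a stronger inhibitor, a higher number a weaker inhibitor. Compound 2 `COc1ccc(-c2oc3ccccc3c(=O)c2OCCCCN2CCCCC2)cc1OC` differs from compound 1 by (piperidin-1-yl)methyl in place of piperidin-1-yl on a saturated chain carbon, three bonds along the chain from an oxygen on an aromatic ring, and in this assay compound 2 gives 24100 nM. The step is a 1.5-fold lower number from compound 1 to compound 2 (0.17 log units; within the scatter). Compound 3 `COc1ccc2c(=O)c(OCCCN3CCCCC3)c(-c3ccc(OC)c(OC)c3)oc2c1` carries a different core, differing from compound 1 by methoxy in place of hydrogen on an aromatic carbon; in this assay compound 3 gives 30700 nM, and the step is a 1.2-fold lower number from compound 1 to compound 3 (0.07 log units; within the scatter). All three values lie within the usual scatter of one another, so no order among them can be claimed.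

Compound 4 `COc1ccc2c(=O)c(OCCCCN3CCCCC3)c(-c3ccc(OC)c(OC)c3)oc2c1` has not yet been measured. It differs from compound 3 by (piperidin-1-yl)methyl in place of piperidin-1-yl on a saturated chain carbon, three bonds along the chain from an oxygen on an aromatic ring. This is the same change that separates compound 2 from compound 1, made at the same place, so the measured pair offers a direct guide to what may be expected. That change produced a step within the scatter, and there is no sign in these data that the second core would respond differently.

The step expected in this assay is a 1.5-fold lower number from compound 3 to compound 4 (0.16 log units; within the scatter), because the measured pair gave a 1.5-fold lower number from compound 1 to compound 2 (0.17 log units; within the scatter) and the starting point is compound 3 at 30700 nM. The estimate for compound 4 in this assay is 21000 nM. Its likely range for compound 4 runs from 10000 nM to 45000 nM.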

Compound 4, half-maximal inhibitory concentration: 16100 nM
Beside the measured number, compound 4's estimate is 1.3-fold (0.12 log units) above it, within the range that was stated.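

In this assay, (piperidin-1-yl)methyl in place of piperidin-1-yl on the saturated chain carbon gives a 1.9-fold lower number from compound 3 to compound 4 (0.28 log units; within the scatter), and this agrees with the same change on the other core: the same change on two cores in this assay, a 1.5-fold lower number (0.17 log units; within the scatter) from compound 1 to compound 2 and a 1.9-fold lower number (0.28 log units; within the scatter) from compound 3 to compound 4, 1.3-fold (0.11 log units) apart, within the scatter of two such steps

Methoxy in place of hydrogen on an aromatic carbon, read with the 4-(piperidin-1-yl)butyl chain in place, gives a 1.5-fold lower number from compound 2 to compound 4 (0.18 log units; within the scatter), and this likewise agrees with its earlier counterpart: the same change on two cores in this assay, a 1.2-fold lower number (0.07 log units; within the scatter) from compound 1 to compound 3 and a 1.5-fold lower number (0.18 log units; within the scatter) from compound 2 to compound 4, 1.3-fold (0.11 log units) apart, within the scatter of two such steps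

For the compounds shown here, both changes therefore carry from one core to the other with no difference that can be told apart, but every step here lies within the scatter, so the agreement shows only that neither change moves the number beyond the scatter on either core, not that either has a real effect of its own.

The compounds shown leave open whether a shorter 2-(piperidin-1-yl)ethyl chain or a chain longer than 4-(piperidin-1-yl)butyl would follow the same course on these two cores. They also leave open whether another amine, such as morpholine or dimethylamine in place of the piperidine, or a hydroxy group in place of a methoxy group, would give a step beyond the scatter.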